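Swapping Methyl for Hydrogen on an Oxygen

The source may hold more compounds than are shown below. What is called first, only, known or untested is meant among the compounds shown, and "the series" means these compounds.

- compound 1 `CONC(=S)N/N=C1\C(=O)N(CN2CCN(c3ccc(Cl)cc3)CC2)c2ccc(C)cc21`: 300000 nM
- compound 2 `CN(C)CN1C(=O)/C(=N\NC(=S)NO)c2cc(F)ccc21`: 599000 nM

Both compounds were tested in an ADME assay on MT4 cells (Homo sapiens) for cytotoxicity, read by spectrophotometry, with a stated time of 5 days; on this read-out higher numbers stand for lower toxicity in this test and lower numbers for higher toxicity in this test. Among the compounds with values here, there, compound 1 gives 300000 nM, and this lies within the usual scatter of the only other measured value, that of compound 2 at 599000 nM. The two numbers therefore cannot be told apart.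

The next compound is compound 3 `Cc1ccc2c(c1)/C(=N/NC(=S)NO)C(=O)N2CN1CCN(c2ccc(Cl)cc2)CC1`, which is reached from compound 1 by one change: hydrogen in place of methyl on an oxygen. In words, hydrogen stands in place of methyl on an oxygen, turning methoxyamino into hydroxyamino. Within the data shown here, no measured step isolates this change in this assay, so the expectation rests only on the closeness of the two known values. No shift beyond the scatter is expected, in either direction. The expected change is a 1.2-fold lower number from compound 1 to compound 3 (0.08 log units; within the scatter). For compound 3 the estimated value is 250000 nM, with an expected range of 80000 nM to 600000 nM.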

Compound 3, half-maximal cytotoxic concentration: 335000 nM
Beside the measured number, compound 3's estimate is 1.3-fold (0.13 log units) below it; the measured number falls inside the stated range.
By their numbers in this assay, from the lowest: compounds 1, 3 and 2 (each within the scatter of the next).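

In this assay, within the data shown here, hydrogen in place of methyl on an oxygen gives a 1.1-fold higher number from compound 1 to compound 3 (0.05 log units; within the scatter) and this is the first measured step at this position. Turning methoxyamino into hydroxyamino on the core of compound 1 thus leaves the read-out within the scatter, something the earlier pair could not show, as compound 1 and compound 2 differ in more than one place. No measurement at hand accounts for this result.

The compounds shown leave open whether an ethyl group, a longer chain or a benzyl group on this oxygen would also stay within the scatter of compound 1 and compound 3. They also leave open whether the same swap of methyl and hydrogen would read alike on the core of compound 2.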